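The compounds below may be only part of what the source reports. "The series", "measured", "known", "first", "only" and "open" are said of these compounds alone.

Measured so far in an assay on isolated protein for binding affinity to adenosine receptor A1 (Bos taurus); on this read-out lower numbers stand for stronger inhibition and higher numbers for weaker inhibition:

- compound 1, `FC(F)(F)c1ccccc1Cn1nnc2c(NC3CCCCC3)nc(-c3ccccc3)nc21`: in this assay compound 1 gives 6800000 nM
- compound 2, `Clc1ccccc1Cn1nnc2c(NC3CCCCC3)nc(-c3ccccc3)nc21`: in this assay compound 2 gives 34000000 nM
- compound 3, `O[C@H]1CCCC[C@@H]1Nc1nc(-c2ccccc2)nc2c1nnn2Cc1ccccc1`: in this assay compound 3 gives 10300000 nM

Compound 3 stands second highest of the three numbers. Its nearest neighbour is compound 1, whose number is lower by an amount within the scatter, so the two cannot be ordered; compound 2 sits furthest away, with a number higher than that of compound 3 by an amount beyond the scatter.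

Among the measured compounds shown here, the single step between measured compounds, a 5.0-fold higher number from compound 1 to compound 2 (0.70 log units; beyond the scatter), concerns a substituent on the benzyl aromatic ring and is modest in size.

Compound 4, `CCCCNc1nc(-c2ccccc2)nc2c1nnn2Cc1ccccc1`, is not yet measured. It differs from compound 3 by butyl in place of 2-hydroxycyclohexyl on a nitrogen on an aromatic ring. For the measured compounds named here, no measured step touches this amine substituent; the only step known, the one from compound 1 to compound 2, changes a different part of the molecule and gives no guidance here. For that reason the expected step of a 1.2-fold higher number from compound 3 to compound 4 (0.07 log units; within the scatter) is set at none beyond the scatter, with a wide range on either side.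

The estimate for compound 4 in this assay is 12000000 nM, between 3500000 nM and 45000000 nM.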

Compound 4, inhibition constant: 11000000 nM
Estimate against measurement, compound 4: 1.1-fold (0.04 log units) above, within the range that was stated.
By their numbers in this assay, from the lowest: compounds 1, 3 and 4 (each within the scatter of the next); then compound 2.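

In this assay, among the compounds shown here, a 1.1-fold higher number from compound 3 to compound 4 (0.03 log units; within the scatter) is the first measured step at this amine substituent, and it lies within the scatter, so compound 3 and compound 4 cannot be ordered. The ring, the hydrogen-bond donor and acceptor and the defined stereocentres of 2-hydroxycyclohexyl are all absent from butyl, yet this exchange leaves no readable difference in this pair, unlike the step on the benzyl aromatic ring, a 5.0-fold higher number from compound 1 to compound 2 (0.70 log units; beyond the scatter). No measurement at hand explains why the two values of this pair cannot be told apart.

For the compounds shown here, open is whether the same absence of a readable step holds for a longer chain such as octyl at this nitrogen, or for a butyl chain ending in a carboxylic acid or an amine, since the pair covers only one exchange on one unsubstituted benzyl form of the shared core. Also open, as far as these compounds go, is whether butyl behaves the same way when the benzyl aromatic ring carries the chloro or trifluoromethyl of compound 2 and compound 1.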